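The compounds below may be only part of what the source reports. "The series", "measured", "known", "first", "only" and "open" are said of these compounds alone.

In an ADME assay on MT4 cells (Homo sapiens) for cytotoxicity, read by MTT assay, with a stated time of 5 days (on this read-out higher numbers stand for lower toxicity in this test and lower numbers for higher toxicity in this test), the three measured compounds read as follows.

- Compound 1 `COc1ccc(NC(=O)CSc2nc(Nc3c(C)cc(/C=C/C#N)cc3C)c3cc(OC)c(OC)cc3n2)cc1` gives > 225000 nM (a limit)
- Compound 2 `COc1cc2nc([S+]([O-])CC(=O)Nc3ccc(C(F)(F)F)cc3)nc(Nc3c(C)cc(/C=C/C#N)cc3C)c2cc1OC` gives 52200 nM (a number)
- Compound 3 `COc1cc2nc([S+]([O-])CC(=O)Nc3ccccc3[N+](=O)[O-])nc(Nc3c(Cl)cc(/C=C/C#N)cc3Cl)c2cc1OC` gives > 199000 nM (a limit)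

Compound 3 has no exact reading, since its > 199000 nM is a limit of the assay and not a number. Among the measured compounds shown here, compound 1 also stands only as a limit, so compound 2 is the one compound with a true number here.

Compound 4 `COc1cc2nc([S+]([O-])CC(=O)Nc3ccccc3C(F)(F)F)nc(Nc3c(Cl)cc(/C=C/C#N)cc3Cl)c2cc1OC` differs from compound 3 in one place, on an aromatic carbon of a six-membered aromatic ring of carbon only, ortho to a large group. There, trifluoromethyl takes the place of nitro, and the count of what changes is trifluoromethyl in place of nitro on an aromatic carbon in full.

For the measured compounds named here, no measured pair shows this exchange on its own, so its size has to be judged indirectly. The nearest guide is compound 2, which also carries a trifluoromethyl group and gives 52200 nM in this assay. That is a single compound and only a weak guide.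

A moderate move toward lower numbers, meaning somewhat higher toxicity, is therefore expected, and the estimated step runs an at least 1.9-fold lower number from compound 3 to compound 4 (0.29 log units; that floor lies within the scatter) in this direction. For compound 4 the expected value is 100000 nM with an estimated range from 35000 nM to 230000 nM overall.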

Compound 4, half-maximal cytotoxic concentration: > 192000 nM
Compound 4 was reported as a limit (the forecaster's own chance of this, stated with the estimate: 45%); middle value at least 1.9-fold (0.28 log units) away from the limit.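

Among the compounds shown here, compound 4 stands only as a limit in this assay, and so does compound 3, so no step between compound 3 and compound 4 can be read. The compounds shown leave open how large a change, and in which direction, trifluoromethyl in place of nitro on an aromatic carbon brings to this read-out.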